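Cytotoxicity notes on the series: from compound 3 to compound 4

The compounds below may be only part of what the source reports. "The series", "measured", "known", "first", "only" and "open" are said of these compounds alone.

Values in an ADME assay on A549 cells (Homo sapiens) for cytotoxicity, read by CellTiter-Glo; on this read-out lower numbers stand for higher toxicity in this test and higher numbers for lower toxicity in this test:
compound 1, `Cc1c(Cc2ccccc2)c(=O)oc2cc(OCC(O)CNCC3CC3)ccc12`: > 100000 nM, a limit of the assay
compound 2, `Cc1c(Cc2ccccc2)c(=O)oc2cc(OCC(O)CNn3ccnn3)ccc12`: > 100000 nM, a limit of the assay
compound 3, `Cc1c(Cc2ccc(F)cc2)c(=O)oc2cc(OCC(O)CN3CCC(C(N)=O)CC3)ccc12`: 89300 nM, the single number in the set

Going by the values given here, compound 3 is the only compound with a number in this assay; the two others sit at the limit of > 100000 nM in this assay, at which 2 of the 3 values shown sit. Among the compounds with values here, the one measured step, a step that the two limits leave unreadable from compound 1 to compound 2, cannot be read because of the limit of > 100000 nM in this assay, at which 2 of the 3 values shown sit. Within the data shown here, it also concerns the amine nitrogen and not the part of the core that changes next, so no measured step bears on the step to compound 4.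

Compound 4, `Cc1c(Cc2ccc(-c3ccccc3)cc2)c(=O)oc2cc(OCC(O)CN3CCC(C(N)=O)CC3)ccc12`, differs from compound 3 by phenyl in place of fluoro on an aromatic carbon. Among the measured compounds shown here, with no comparable step in hand, the expectation rests on the value of compound 3 alone: a step within the usual scatter is expected, a 1.3-fold lower number from compound 3 to compound 4 (0.11 log units; within the scatter), with a fair chance that the assay again reports only a limit. For compound 4 in this assay the estimate is 70000 nM, between 25000 nM and 150000 nM.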

Compound 4, half-maximal cytotoxic concentration: > 100000 nM
Compound 4: a limit, no number (the forecaster's own chance of this, stated with the estimate: 35%); middle value at least 1.4-fold (0.15 log units) from the limit.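

Going by these compounds alone, at this position, on an aromatic carbon para to a large group, the change from 4-fluorophenyl to 4-phenylphenyl gives the first readable step on this part of the molecule, and in this assay it stands as an at least 1.1-fold higher number from compound 3 to compound 4 (0.04 log units; that floor lies within the scatter). Six heavy atoms and one more six-membered aromatic ring of carbon only, in place of a single fluorine, thus bring no sign of higher toxicity in this test. Compound 4 gives > 100000 nM, a limit of the assay and not a number, so the step has a floor and no readable size, and the series now stands as follows: the limit of > 100000 nM in this assay, at which 3 of the 4 values shown sit.

Open, on these data alone, is whether an amine or a carboxylic acid on an aromatic carbon at this same place, in place of the phenyl of compound 4, would give a number in this assay at all. Within the data shown here, with compound 3 still the only compound carrying a number, it also stays open whether a change on the amine nitrogen, such as a longer chain, can bring a lower number.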